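The source may report more compounds than this note shows. Statements on the series, on what has been measured and on what is new or still open speak of the compounds shown alone.

Compound 1 `CS(=O)(=O)OC1CCC(CN2CCN(c3cc(=O)c4cc(C(F)(F)F)cc([N+](=O)[O-])c4s3)CC2)CC1`: > 64 ug/mL
Compound 2 `O=c1cc(N2CCN(CC3CCC(NS(=O)(=O)c4ccccc4)CC3)CC2)sc2c([N+](=O)[O-])cc(C(F)(F)F)cc12`: > 64 ug/mL

Both compounds were tested in an ADME assay on Vero cells (Chlorocebus sabaeus) for cytotoxicity, read by MTT assay, with a stated time of 48 h; on this read-out lower numbers stand for stronger inhibition and higher numbers for weaker inhibition. On these data alone, compound 2 gives > 64 ug/mL, which is a limit and not a number, so its true value is unknown. Compound 3 `O=C(OC1CCC(CN2CCN(c3cc(=O)c4cc(C(F)(F)F)cc([N+](=O)[O-])c4s3)CC2)CC1)c1cccc(F)c1` keeps the shared core and changes one group: ((3-fluorophenyl)carbonyl)oxy in place of (phenylsulfonyl)amino on a saturated ring carbon.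

For the measured compounds named here, only one measured step bears on this change: a step that the two limits leave unreadable from compound 1 to compound 2. It altered the group on the same saturated ring carbon, but it gives no size to carry over. The remaining evidence is the limit of > 64 ug/mL in this assay, at which 2 of the 2 values shown sit. No step beyond the usual scatter is therefore expected in either direction, and another limit is the likeliest report. The estimated step is a step that the limit leaves unreadable from compound 2 to compound 3. For compound 3 the expected value is 70 ug/mL, with an estimated range from 32 ug/mL to 128 ug/mL.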

Compound 3, half-maximal inhibitory concentration: > 64 ug/mL
Compound 3: a limit, no number (the forecaster's own chance of this, stated with the estimate: 80%); the middle value is on the limit's open side.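

For the compounds shown here, compound 1, compound 2 and compound 3 each give a limit and not a number in this assay, and no step between them can be read. The compounds shown leave open where each true value lies, and whether changing the group on the saturated ring carbon shifts it at all.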